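Swapping the dimethoxyphenyl group for 4-cyanophenyl

A few compounds are considered here, and "the series" means these few. Any claim that something is new, unique, unknown or untested is made for them only; others in the source may bear on it.

compound 1 `COc1ccc(OC)c(/C=C/C(=O)Nc2cc3c(Nc4ccc(F)c(Cl)c4)ncnc3cc2OC)c1`: 11200 nM
compound 2 `COc1ccc(/C=C/C(=O)Nc2cc3c(Nc4ccc(F)c(Cl)c4)ncnc3cc2OC)c(OC)c1`: 33300 nM

In a functional assay on A549 cells (Homo sapiens) for cytotoxicity, read by MTT assay, with a stated time of 72 h (on this read-out lower numbers stand for stronger inhibition and higher numbers for weaker inhibition), compound 2 holds the higher of the two numbers, at 33300 nM. Compound 3 `COc1cc2ncnc(Nc3ccc(F)c(Cl)c3)c2cc1NC(=O)/C=C/c1ccc(C#N)cc1` carries 4-cyanophenyl in place of 2,4-dimethoxyphenyl on a double-bonded chain carbon bound to a double-bonded chain carbon. For the measured compounds named here, the only measured guide is the modest step of a 3.0-fold higher number from compound 1 to compound 2 (0.47 log units; beyond the scatter), and no measured compound carries 4-cyanophenyl. The expected step is a 1.7-fold lower number from compound 2 to compound 3 (0.22 log units; within the scatter), a small move toward a lower number, and its direction is only a weak guess. For compound 3 the estimate is 20000 nM, with an expected range from 6000 nM to 60000 nM.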

Compound 3, half-maximal inhibitory concentration: "not active" (no number reported)
Nothing numeric was reported for compound 3; no gap can be computed for the estimate.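

For the compounds shown here, compound 3 is reported only as "not active", with no number, so no step from compound 2 can be read. Nothing measured here explains that result. The compounds shown leave open how far compound 3 actually lies from compound 2.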